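The source may hold more compounds than are shown below. What is called first, only, known or untested is meant among the compounds shown, and "the series" means these compounds.

Measured compounds in an assay on isolated protein for inhibition of cathepsin S (Homo sapiens), read by fluorescence; a lower number here means a stronger inhibitor, a higher number a weaker inhibitor:
compound 1 `CCC(C=O)NC(=O)c1cccc(C(F)(F)F)c1C`, 18 nM
compound 2 `CC(NC(=O)c1ccc(OCc2ccccn2)c(C(F)(F)F)c1Cl)C(=O)C(N)=O`, 4.8 nM
compound 3 `CCC(NC(=O)c1ccc(OCc2ccccn2)c(C(F)(F)F)c1Cl)C(=O)C(N)=O`, 1.1 nM

Compound 1 stands highest of the three numbers in this assay; compound 2 lies nearest and compound 3 furthest below it. Going by the values given here, the one step within the set, a 4.4-fold lower number from compound 2 to compound 3 (0.64 log units; beyond the scatter), concerns the chain and not the ring.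

Compound 4 `CCC(C=O)NC(=O)c1cccc(C(F)(F)F)c1Cl` differs from compound 1 only at the ring: chloro in place of methyl on an aromatic carbon. Among the compounds with values here, no measured step covers this exchange; compounds 2 and 3 carry chloro there but differ from compound 1 in several other places, so their values give no direct reading of the swap. The expectation for compound 4 is therefore a step no larger than the scatter, a 1.2-fold lower number from compound 1 to compound 4 (0.08 log units; within the scatter). Compound 4 is estimated at 15 nM, within 5 nM to 45 nM.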

Compound 4, half-maximal inhibitory concentration: 31 nM
Beside the measured number, compound 4's estimate is 2.1-fold (0.32 log units) below it; the range from low to high includes it.
By their numbers in this assay, from the lowest: compound 3; then compound 2; then compounds 1 and 4 (each within the scatter of the next).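

In this assay, chloro in place of methyl on this aromatic carbon gives a 1.7-fold higher number from compound 1 to compound 4 (0.24 log units; within the scatter). Going by these compounds alone, this is the first direct reading at this position, and on the core of compound 1 it does not separate the two groups. Nothing available bears on the reason for this result.

Still open, on these data alone, is whether hydrogen, bromo or methoxy at this position would separate from methyl and chloro. Also open, as far as these compounds go, is whether the same exchange reads alike on the core of compound 3.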